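The source may hold more compounds than are shown below. What is called first, only, known or untested is meant among the compounds shown, and "the series" means these compounds.

Measured compounds in the series:

Compound 1 `Cc1ccccc1-c1nn(-c2ccc(Cl)cc2)cc1CNCCN1CCN(C)CC1` — 17000 nM
Compound 2 `CN1CCN(CCNCc2cn(-c3ccc(F)cc3F)nc2-c2cccc(Cl)c2)CC1` — 15000 nM
Compound 3 `CN1CCN(CCCNCc2cn(-c3ccc(C(F)(F)F)cc3)nc2-c2ccc(OC(F)(F)F)cc2)CC1` — 2300 nM

Notes. In an ADME assay on Huh-7 cells (Homo sapiens) for cytotoxicity (on this read-out lower numbers stand for higher toxicity in this test and higher numbers for lower toxicity in this test), compound 1 gives 17000 nM, the highest of the three numbers recorded. Compound 2 gives 15000 nM, which lies within the scatter of compound 1, so the two cannot be ranked. Among the compounds with values here, compound 3 gives 2300 nM, a lower number that falls beyond the scatter; no single-point step connects compound 3 to compound 1, so only the two values themselves are on record.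

The step under consideration leads to compound 4 `Cc1ccccc1-c1nn(-c2ccc(N)cc2)cc1CNCCN1CCN(C)CC1`, which is not yet measured in this assay. The change from compound 1 is amino in place of chloro on an aromatic carbon. Within the data shown here, no pair of measured compounds shows this same exchange, so there is nothing to anchor the direction or size of the step. Given that, the expectation is a step from compound 1 to compound 4 of no change at the digits printed from compound 1 to compound 4 (within the scatter), that is, none beyond the scatter. Among the measured compounds shown here, compound 4 is estimated at 17000 nM, with a range from 8000 nM to 36000 nM, because compound 1 gives 17000 nM and no recorded step argues for a move away from it.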

Compound 4, half-maximal cytotoxic concentration: > 20000 nM
Compound 4: only a limit was reported (the forecaster's own chance of this, stated with the estimate: 10%); middle value at least 1.1-fold (0.07 log units) from the limit.
By their numbers in this assay, from the lowest: compound 3; then compounds 2 and 1 (each within the scatter of the next). At a limit, above all of these: compound 4.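

In this assay compound 4 is recorded only as a limit, > 20000 nM. Within the data shown here, the exchange of chloro for amino, the only single-place step, reads as an at least 1.1-fold higher number from compound 1 to compound 4 (0.07 log units; that floor lies within the scatter), so this position on the aromatic ring accepts 4-aminophenyl in place of 4-chlorophenyl with no drop in the number. The size of any rise cannot be told, and the step cannot be separated from the scatter, since the reading for compound 4 stops at the top of the range: the limit of > 20000 nM in this assay, at which 1 of the 4 values shown sits.

Going by these compounds, whether a hydroxyl or a methoxy group at this place would read like amino stays open. Also open, on these data alone, is whether amino in place of chloro moves the number on a compound that starts further from the limit.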